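Swapping the Aryl Group on the Shared Core

A few compounds are considered here, and "the series" means these few. Any claim that something is new, unique, unknown or untested is made for them only; others in the source may bear on it.

Compound 1 `Cc1cc(=O)n(-c2ccccc2C(F)(F)F)nc1C(=O)Nc1ccc(Oc2ncnc3ccsc23)cc1`: 8850 nM
Compound 2 `Cc1ccc(-n2nc(C(=O)Nc3ccc(Oc4ncnc5ccsc45)cc3)c(C)cc2=O)cc1`: 11500 nM
Compound 3 `Cc1cc(=O)n(-c2ccccc2C(F)(F)F)nc1C(=O)Nc1ccc(Oc2ncnc3sccc23)cc1`: 19900 nM

These three numbers come from a functional assay on A549 cells (Homo sapiens) for cytotoxicity, read by MTT assay, with a stated time of 72 h; on this read-out higher numbers stand for weaker inhibition and lower numbers for stronger inhibition. Compound 3 gives the highest of the three; the step of a 2.2-fold higher number from compound 1 to compound 3 (0.35 log units; beyond the scatter) is modest, while compound 2 lies within the scatter of compound 3.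

Compound 4 `Cc1ccc(-n2nc(C(=O)Nc3ccc(Oc4ncnc5sccc45)cc3)c(C)cc2=O)cc1` differs from compound 3 by 4-methylphenyl in place of 2-(trifluoromethyl)phenyl on an aromatic nitrogen. The same exchange has been measured once, as a 1.3-fold higher number from compound 1 to compound 2 (0.11 log units; within the scatter), so no step beyond the scatter is expected here either. The expected step, a 1.2-fold higher number from compound 3 to compound 4 (0.08 log units; within the scatter), stays within that scatter. Compound 4 is therefore expected to give about 24000 nM in this assay, within a range from 11000 nM to 52000 nM.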

Compound 4, half-maximal inhibitory concentration: > 40000 nM
Compound 4: only a limit was reported (the forecaster's own chance of this, stated with the estimate: 25%); middle value at least 1.6-fold (0.22 log units) away from the limit.
By their numbers in this assay, from the lowest: compounds 1, 2 and 3 (each within the scatter of the next, the first and the last beyond it). At a limit, above all of these: compound 4.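

The value for compound 4 is a limit, not a number. At this aromatic nitrogen, 4-methylphenyl in place of 2-(trifluoromethyl)phenyl gives an at least 2.0-fold higher number from compound 3 to compound 4 (0.30 log units; that floor lies within the scatter), so this change is still not shown to exceed the scatter. Exchanging the group on the oxygen with 4-methylphenyl in place gives an at least 3.4-fold higher number from compound 2 to compound 4 (0.54 log units; beyond the scatter), so that exchange now raises the number beyond the scatter with both aryl groups.

Going by these compounds, whether the aryl change is equal on the two cores cannot be read: the same change on two cores in this assay, a 1.3-fold higher number (0.11 log units; within the scatter) from compound 1 to compound 2 and an at least 2.0-fold higher number (0.30 log units; that floor lies within the scatter) from compound 3 to compound 4; the limit leaves it open whether they differ How a 4-chlorophenyl or 4-aminophenyl group at this nitrogen would read also stays open.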